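This account rests on a few compounds, and the source may have more. Where it says the series, first, only, none or still open, it means among the compounds named here.

In a functional assay on PC-3 cells (Homo sapiens) for inhibition, read by MTT assay, with a stated time of 48 h (a higher number here means a weaker inhibitor, a lower number a stronger inhibitor), compound 3 `CC1CN(C(=O)CN2C(=O)S/C(=C\c3nc4ccccc4n3C(C)C)C2=O)CC(C)O1` gives only a limit of the assay, > 50000 nM. Compound 2 `CC(C)n1c(/C=C2\SC(=O)N(CC(=O)N3CCCCC3)C2=O)nc2ccccc21` also stops at a limit there, > 50000 nM. Among the measured compounds shown here, the single measured step, a step that the two limits leave unreadable from compound 2 to compound 3, is thus of unreadable size, and the same holds for the whole set, since (the limit of > 50000 nM in this assay, at which 3 of the 3 values shown sit). Compound 1 `CCn1c(/C=C2\SC(=O)N(CC(=O)Nc3cc(C(C)(C)C)on3)C2=O)nc2ccccc21` likewise sits at a limit in this assay, > 50000 nM. Compound 4 `CC(C)n1c(/C=C2\SC(=O)N(CC(=O)Nc3cc(C(C)(C)C)on3)C2=O)nc2ccccc21` differs from compound 3 by (5-(tert-butyl)-1,2-oxazol-3-yl)amino in place of 2,6-dimethylmorpholin-4-yl on a carbonyl carbon. For the measured compounds named here, compound 1 carries this same entering group on a closely related core and reaches only a limit, so no measured step bears on the change in a readable way and no direction can be drawn. Compound 4 is therefore expected to stay at a limit, with an estimated 80000 nM lying between 30000 nM and 300000 nM. The expected step from compound 3 is a step that the limit leaves unreadable from compound 3 to compound 4, not readable beyond the scatter.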

Compound 4, half-maximal inhibitory concentration: > 50000 nM
Compound 4: no number, only a limit; the forecaster's own chance of this, stated with the estimate: 85%; the middle value lies beyond the limit too.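

Compound 4 sits at a limit, as do compound 1, compound 2 and compound 3, so no step to compound 4 can be read in this assay: the limit of > 50000 nM in this assay, at which 4 of the 4 values shown sit.

The compounds shown leave open how large any of these changes is, and in which direction it acts.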